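Dibromination of the hydroxyphenyl ring in an acylhydrazone series

A few compounds are considered here, and "the series" means these few. Any claim that something is new, unique, unknown or untested is made for them only; others in the source may bear on it.

Compound 1, `C/C(=N\NC(=O)c1cccc(S(=O)(=O)N2CCOCC2)c1)c1cccc(N)c1`, in a functional assay on PC-3 cells (Homo sapiens) for antiproliferative activity, read by MTT assay, with a stated time of 72 h (on this read-out higher numbers stand for weaker inhibition and lower numbers for stronger inhibition), gives > 100000 nM, which is a limit of the assay and not a number.
Compound 2, `C/C(=N\NC(=O)c1cccc(S(=O)(=O)N2CCOCC2)c1)c1cc(Br)ccc1O`, in this assay gives 6890 nM.
Compound 3, `O=C(N/N=C/c1ccccc1O)c1cccc(S(=O)(=O)N2CCOCC2)c1`, in this assay gives 13800 nM.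

Of the two numbers that are not limits, compound 3 has the higher one, with compound 2 as its nearest neighbour within the scatter. Compound 4, `O=C(N/N=C/c1cc(Br)cc(Br)c1O)c1cccc(S(=O)(=O)N2CCOCC2)c1`, differs from compound 3 in one place: 3,5-dibromo-2-hydroxyphenyl in place of 2-hydroxyphenyl on a carbon with a double bond to nitrogen.

Among the compounds with values here, one measured step bears on this, the change an at least 14-fold lower number from compound 1 to compound 2 (1.16 log units; beyond the scatter), which also brings in a bromine-bearing hydroxyphenyl, though it replaces an aminophenyl rather than adding bromine alone; since compound 1 sits at the limit of > 100000 nM in this assay, at which 1 of the 3 values shown sits, that step is only a lower bound. Within the data shown here, compounds 2 and 3 differ in two places, so their values show only that a brominated ring sits alongside a number within the scatter of the unbrominated one.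

Compound 4 is therefore expected to show a modest lowering, a 2.8-fold lower number from compound 3 to compound 4 (0.44 log units; beyond the scatter), estimated at 5000 nM with a range from 1500 nM to 18000 nM.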

Compound 4, half-maximal inhibitory concentration: 9700 nM
Beside the measured number, compound 4's estimate is 1.9-fold (0.29 log units) below it; low and high end bracket the measured number.
By their numbers in this assay, from the lowest: compounds 2, 4 and 3 (each within the scatter of the next). At a limit, above all of these: compound 1.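

Within the data shown here, compound 4 is the first pair to isolate bromine on this ring, with the hydroxy group kept and nothing else changed: in this assay, the change to 3,5-dibromo-2-hydroxyphenyl gives a 1.4-fold lower number from compound 3 to compound 4 (0.15 log units; within the scatter). On the carbon with a double bond to nitrogen, then, adding the two bromines alone does not move the number beyond the scatter, and it does not repeat the large step seen when a bromine-bearing hydroxyphenyl replaced the aminophenyl. Nothing measured here bears on why the number holds.

As far as these compounds go, it remains open what an amine or a methoxy group in place of the hydroxy group on the dibrominated ring would give. The two bromines also remain unseparated, since a ring with only one on the rest of compound 3 would be needed to tell them apart.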